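The source may hold more compounds than are shown below. What is called first, only, known or untested is meant among the compounds shown, and "the series" means these compounds.

Compound 1 `COc1cc(Br)cc(/C=C/C(=O)c2ccccc2)c1O` was examined in an ADME assay on MCF-10A cells (Homo sapiens) for cytotoxicity, read by sulforhodamine B assay, with a stated time of 72 h, tested at 30 uM (a higher number here means a stronger effect of the compound at the concentration tested, a lower number a weaker effect), where compound 1 gives 40.7%. Its only measured relative, compound 2 `COc1cc(Br)cc(/C=C/C(=O)c2ccc(Cl)cc2)c1O`, carries a chloro in place of hydrogen on an aromatic carbon, and in this assay compound 2 gives 47.8%. For the measured compounds named here, the step of a number 7.1 percentage points higher from compound 1 to compound 2 (within the scatter) is the single measured step, and it lies within the scatter. Among the two numbers compound 1 stands lowest, yet its distance to compound 2 is within the scatter, so no order between them can be claimed.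

Compound 3 `COc1cccc(C(=O)/C=C/c2cc(Br)cc(OC)c2O)c1` has yet to be measured in this assay. It differs from compound 1 in one place: methoxy in place of hydrogen on an aromatic carbon. Going by the values given here, the one measured step that bears on this, a number 7.1 percentage points higher from compound 1 to compound 2 (within the scatter), likewise exchanged a hydrogen of the ring for another group and stayed within the scatter. On that basis no step beyond the scatter is expected in this assay, in either direction. The expected step is therefore a number 1.3 percentage points higher from compound 1 to compound 3 (within the scatter). For compound 3 the estimated value in this assay is 42%, with a range from 28% to 56%.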

Compound 3, a percentage reported as activity, at one concentration (the size of the read-out at that concentration, not a potency): 47%
For compound 3 the middle estimate is 5 percentage points below the measured one; the range from low to high includes it.
By their numbers in this assay, from the lowest: compounds 1, 3 and 2 (each within the scatter of the next).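

In this assay, methoxy on an aromatic carbon, meta to a large group, goes with a number 6.3 percentage points higher from compound 1 to compound 3 (within the scatter), so this second exchange of a ring hydrogen, now for a group of 2 heavy atoms with 1 hydrogen-bond acceptor, also stays inside the usual variation. Read with a number 7.1 percentage points higher from compound 1 to compound 2 (within the scatter), it leaves two exchanges on the shared core, chloro and methoxy, neither of which moves the read-out beyond that variation at the one concentration tested. No measurement shown bears on the reason for this result.

From the compounds shown here alone, whether an amine or a carboxylic acid on this aromatic carbon would give a step beyond the scatter remains open, as does the outcome for a longer chain such as butoxy in place of methoxy. The compounds shown also leave open how the methoxy and chloro exchanges would compare at other concentrations, since a single-concentration read-out gives no potency.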